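Swapping the group on sulfur in a weakly active series

A few compounds are considered here, and "the series" means these few. Any claim that something is new, unique, unknown or untested is made for them only; others in the source may bear on it.

Values in a functional assay on PC-3 cells (Homo sapiens) for inhibition, read by MTT assay, with a stated time of 72 h; on this read-out lower numbers stand for stronger inhibition and higher numbers for weaker inhibition:
compound 1 `CN1CCN(c2cc(C(F)(F)F)nc(SCc3ccc(C(F)(F)F)cc3)n2)CC1`: 34700 nM
compound 2 `FC(F)(F)c1ccc(CSc2nc(Sc3ncccn3)cc(C(F)(F)F)n2)cc1`: > 50000 nM (a limit of the assay)
compound 3 `FC(F)(F)c1ccc(CSc2nc(Sc3nnnn3-c3ccccc3)cc(C(F)(F)F)n2)cc1`: 45300 nM

Compound 3 at 45300 nM lies within the scatter of compound 1 at 34700 nM. Within the data shown here, these are the only two numbers available, since compound 2 gives only a limit.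

Compound 4 `FC(F)(F)c1ccc(CSc2nc(Sc3nncs3)cc(C(F)(F)F)n2)cc1` carries 1,3,4-thiadiazol-2-yl in place of 1-phenyl-1H-tetrazol-5-yl on a sulfur.

Among the measured compounds shown here, the closest precedent is an at least 1.1-fold lower number from compound 2 to compound 3 (0.04 log units; that floor lies within the scatter), a swap on the same sulfur. The other measured step, an at least 1.4-fold higher number from compound 1 to compound 2 (0.15 log units; that floor lies within the scatter), replaces 4-methylpiperazin-1-yl on an aromatic carbon. Both steps are known only as floors due to the limit of > 50000 nM in this assay, at which 1 of the 3 values shown sits.

With no measured step beyond the scatter, none is expected in this assay for this change, and the estimate stays close to compound 3 at 45300 nM. The expected step is a 1.1-fold lower number from compound 3 to compound 4 (0.05 log units; within the scatter). Compound 4 is estimated at 40000 nM, with an expected range of 20000 nM to 70000 nM.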

Compound 4, half-maximal inhibitory concentration: 7880 nM
Compound 4: the middle estimate sits 5.1-fold (0.71 log units) above what was measured, and the stated range ends above it.
By their numbers in this assay, from the lowest: compound 4; then compounds 1 and 3 (each within the scatter of the next). At a limit, above all of these: compound 2.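

In this assay, the group on this sulfur can move the number beyond the scatter: 1,3,4-thiadiazol-2-yl in place of 1-phenyl-1H-tetrazol-5-yl gives a 5.7-fold lower number from compound 3 to compound 4 (0.76 log units; beyond the scatter). In place of pyrimidin-2-yl the same group gives an at least 6.3-fold lower number from compound 2 to compound 4 (0.80 log units; beyond the scatter), and as (1,3,4-thiadiazol-2-yl)sulfanyl in place of 4-methylpiperazin-1-yl on the aromatic carbon it gives a 4.4-fold lower number from compound 1 to compound 4 (0.64 log units; beyond the scatter), which sets compound 4 apart as the strongest of the four shown. The step from compound 2 is only a floor, as its value is a limit: the limit of > 50000 nM in this assay, at which 1 of the 4 values shown sits.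

Still open, on these data alone, is whether the gain follows the sulfur in the entering ring or the loss of the six-membered aromatic ring of carbon, since the change from compound 3 brings both. A 1-methyl-1H-tetrazol-5-yl or a 1,3,4-oxadiazol-2-yl on the same sulfur would help to separate the two.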